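The source may report more compounds than this note shows. Statements on the series, on what has been measured and on what is new or still open speak of the compounds shown alone.

Measured compounds and their values in a functional assay on HeLa cells (Homo sapiens) for cytotoxicity, read by MTT assay, with a stated time of 72 h; on this read-out higher numbers stand for weaker inhibition and lower numbers for stronger inhibition:

- compound 1 `Cc1ccc(CSc2cc(Cl)c(C)cc2S(=O)(=O)/N=C(\N)n2nc(C)cc2-c2ccccc2)cc1` — 62000 nM
- compound 2 `Cc1cc(S(=O)(=O)/N=C(\N)n2nccc2-c2ccccc2)c(SCc2ccc(C(F)(F)F)cc2)cc1Cl` — 17000 nM
- compound 3 `Cc1cc(S(=O)(=O)/N=C(\N)n2nccc2-c2ccccc2)c(SCc2cccc3ccccc23)cc1Cl` — 3000 nM

Compound 3 gives the lowest number of the three in this assay; compound 2 stands nearest to it and compound 1 furthest, both steps beyond the scatter. The next compound, compound 4 `Cc1ccc(CSc2cc(Cl)c(C)cc2S(=O)(=O)/N=C(\N)n2nccc2-c2ccccc2)cc1`, differs from compound 3 by 4-methylphenyl in place of naphthalen-1-yl on a saturated chain carbon bound to a sulfur.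

Within the data shown here, the only measured step on the same position is a 5.7-fold lower number from compound 2 to compound 3 (0.75 log units; beyond the scatter), where the larger ring pair replaced a single ring and the number fell beyond the scatter. Compound 4 goes the other way, back to a single ring of the kind carried by compound 1, though compound 1 also carries an extra methyl on the core and no step to it is shown. On this basis a rise beyond the scatter is expected from compound 3 to compound 4 in this assay, of roughly the size of a 6.7-fold higher number from compound 3 to compound 4 (0.82 log units; beyond the scatter). The estimate for compound 4 in this assay is 20000 nM, with a range from 7000 nM to 60000 nM.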

Compound 4, half-maximal inhibitory concentration: 17000 nM
Estimate against measurement, compound 4: 1.2-fold (0.07 log units) above; the range from low to high includes it.
By their numbers in this assay, from the lowest: compound 3; then compounds 2 and 4 (each within the scatter of the next); then compound 1.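

In this assay, the step of a 5.7-fold higher number from compound 3 to compound 4 (0.75 log units; beyond the scatter) shows that the advantage of naphthalen-1-yl is not tied to the trifluoromethyl-bearing ring alone, as it also holds against 4-methylphenyl. The step of no change at the digits printed from compound 2 to compound 4 (within the scatter) places the two single rings at one level, so methyl and trifluoromethyl on the aromatic carbon cannot be told apart here, and only the larger ring pair stands apart among the three groups compared at this place. The step of a 3.6-fold lower number from compound 1 to compound 4 (0.56 log units; beyond the scatter) adds the first reading from elsewhere on the core, with hydrogen in place of methyl on an aromatic carbon mattering about as much as the ring change.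

Still open, as far as these compounds go, is how a saturated ring such as cyclohexyl, or a nitrogen-containing ring such as pyridine, would read at this place, and whether naphthalen-1-yl keeps its advantage on the core of compound 1. Nothing at hand bears on why these steps take the sizes they do.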